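A few compounds are considered here, and "the series" means these few. Any claim that something is new, unique, unknown or untested is made for them only; others in the source may bear on it.

Among the measured compounds shown here, compound 2 `O=S(=O)(NCCNc1nccc(-c2c(-c3cccc(F)c3)nc3sccn23)n1)c1ccc(Cl)cc1` gives 18600 nM in a functional assay on A-375 cells (Homo sapiens) for cytotoxicity, read by MTT assay (a lower number here means a stronger inhibitor, a higher number a weaker inhibitor), the highest of the two numbers measured so far; the nearest is compound 1 `O=S(=O)(NCCCNc1nccc(-c2c(-c3cccc(F)c3)nc3sccn23)n1)c1ccc(Br)cc1`, which in this assay gives 7040 nM. The change to compound 3 `O=S(=O)(NCCCNc1nccc(-c2c(-c3cccc(F)c3)nc3sccn23)n1)c1ccc(Cl)cc1` is (((4-chlorophenyl)sulfonyl)amino)methyl in place of ((4-chlorophenyl)sulfonyl)amino on a saturated chain carbon, two bonds along the chain from a nitrogen on an aromatic ring. For the measured compounds named here, the only measured step that bears on it, a 2.6-fold higher number from compound 1 to compound 2 (0.42 log units; beyond the scatter), combines this chain change with a swap of bromine for chlorine, so it reverses only part of that step. A modest move toward a lower number is therefore expected, as a 2.1-fold lower number from compound 2 to compound 3 (0.32 log units; beyond the scatter). Compound 3 is estimated at 9000 nM, within 4000 nM to 20000 nM.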

Compound 3, half-maximal inhibitory concentration: 5900 nM
Beside the measured number, compound 3's estimate is 1.5-fold (0.18 log units) above it; measured number inside the range.
By their numbers in this assay, from the lowest: compounds 3 and 1 (each within the scatter of the next); then compound 2.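

In this assay the chain change can now be read alone: with the chloro group kept, (((4-chlorophenyl)sulfonyl)amino)methyl in place of ((4-chlorophenyl)sulfonyl)amino on this saturated chain carbon gives a 3.2-fold lower number from compound 2 to compound 3 (0.50 log units; beyond the scatter). Chloro in place of bromo on an aromatic carbon gives a 1.2-fold lower number from compound 1 to compound 3 (0.08 log units; within the scatter), so the chain change, not the halogen swap, carries the earlier difference. No evidence on the cause of this shift is at hand.

As far as these compounds go, whether a longer chain lowers the number further remains open. So does the effect of a methoxy group in place of the halogen.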